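This account rests on a few compounds, and the source may have more. Where it says the series, first, only, none or still open, it means among the compounds named here.

Measured compounds in a functional assay on the whole organism (strain Wistar) with Rattus norvegicus as the target, with a stated time of 4 h; on this read-out higher numbers stand for an effect only at larger amounts of compound and lower numbers for an effect already at smaller amounts:
compound 1 `C=C(C)[C@@H]1CC=C(C)/C(=N/NC(=O)Nc2nnc(-c3ccc([N+](=O)[O-])cc3)o2)C1`, which gives 300 mg/kg
compound 2 `C=C(C)[C@@H]1CC=C(C)/C(=N/NC(=O)Nc2nnc(-c3ccc(O)cc3)o2)C1`, which gives 300 mg/kg
compound 3 `CC(C)=CC/C=C(/C)C/C=N/NC(=O)Nc1nnc(-c2ccc([N+](=O)[O-])cc2)o1`, which gives 300 mg/kg

Compounds 1 and 2 share one core and differ in a single place: hydroxy in place of nitro on an aromatic carbon. On this assay the step gave no change at the digits printed from compound 1 to compound 2 (within the scatter). Compound 3 is built on a different core; how the two cores differ is not broken down here. Its minimum effective dose stands level with those of compounds 1 and 2, the gaps all lying within the usual scatter, so no order among the three can be read off.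

Compound 4 `CC(C)=CC/C=C(/C)C/C=N/NC(=O)Nc1nnc(-c2ccc(O)cc2)o1` has not yet been measured. It differs from compound 3 by hydroxy in place of nitro on an aromatic carbon. Within the data shown here, the place lines of the two changes read the same word for word, so this is the same change as the one from compound 1 to compound 2, now made on the core of compound 3.

For compound 4 the expected step is no change at the digits printed from compound 3 to compound 4 (within the scatter), set beside no change at the digits printed from compound 1 to compound 2 (within the scatter); the expectation rests on that earlier step and on the level value of compound 3, 300 mg/kg. Compound 4 is therefore estimated at 300 mg/kg, with the expected range running from 150 mg/kg to 600 mg/kg.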

Compound 4, minimum effective dose: 300 mg/kg
Compound 4: the middle estimate sits on the measured number at the digits printed; low and high end bracket the measured number.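

In this assay hydroxy in place of nitro on an aromatic carbon gives no change at the digits printed from compound 3 to compound 4 (within the scatter) on the core of compound 3. Set beside the step on the core of compound 1, the change reads the same on both cores: the same change on two cores in this assay, no change at the digits printed (within the scatter) from compound 1 to compound 2 and no change at the digits printed (within the scatter) from compound 3 to compound 4, 1.0-fold (0.00 log units) apart, within the scatter of two such steps

This agreement covers only the 4-nitrophenyl to 4-hydroxyphenyl change on these two cores. Neither step has a size beyond the scatter, so the series does not show whether a change with a clear effect on the minimum effective dose would carry from one core to the other, and it assigns no contribution to either group.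

The compounds shown leave open how an amine, a methoxy group or a carboxylic acid in the same place on the aromatic ring would read in this assay on either core. Also open, going by these compounds, is whether a longer chain on the core of compound 3 would move the minimum effective dose away from the level shared by these four compounds.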